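This account rests on a few compounds, and the source may have more. Where it says the series, first, only, none or still open, it means among the compounds named here.

Series notes, lipophilicity. Compound 1 `CC(=O)NC[C@H]1CN(c2ccc(OC[C@H](O)CNc3ccccn3)c(F)c2)C(=O)O1` and compound 2 `CC(=O)NC[C@H]1CN(c2ccc(OC[C@@H](O)CNC3CC3)c(F)c2)C(=O)O1` share a core and differ only in the group on the saturated chain carbon bound to an oxygen on the aromatic ring. Within the data shown here, in a physicochemical assay for lipophilicity, read by HPLC (a lower number here means a more polar compound, a higher number a more lipophilic compound), compound 1 gives 1.6, while compound 2 gives 0.02; the single measured step is a number 1.58 log units lower from compound 1 to compound 2 (beyond the scatter), the 2-(cyclopropylamino)-1-hydroxyethyl group in place of the 1-hydroxy-2-((pyridin-2-yl)amino)ethyl group. Among the measured compounds shown here, compound 2 therefore stands lowest of the two numbers so far, with compound 1 the nearest and well above it.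

Compound 3 `CC(=O)NC[C@H]1CN(c2ccc(OC[C@H](O)CNC3CC3)c(F)c2)C(=O)O1` is now to be read in this assay. The change from compound 2 is the two compounds have the same atoms and bonds and differ only in configuration as drawn: 1 of 2 stereo elements differ; a stereocentre at a saturated chain carbon is drawn S in compound 2 and R in compound 3; no atom leaves and none enters, so the cyclopropylamino group and the hydroxyl group are retained and only the drawn configuration at that one centre is altered. For the measured compounds named here, no measured step concerns a change of configuration alone; the step from compound 1 to compound 2 exchanged groups and does not bear on it. A change in this assay beyond the scatter is not expected, and the step from compound 2 to compound 3 is estimated at a number 0.03 log units higher from compound 2 to compound 3 (within the scatter). For compound 3 the expected value in this assay is 0.05, with a range from -0.3 to 0.4.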

Compound 3, partition coefficient: -0.1
Beside the measured number, compound 3's estimate is 0.15 log units above it, and the stated range covers the measured number.
By their numbers in this assay, from the lowest: compounds 3 and 2 (each within the scatter of the next); then compound 1.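

In this assay, the stereocentre at a saturated chain carbon, drawn S in one compound and R in the other, gives a number 0.12 log units lower from compound 2 to compound 3 (within the scatter), so with the cyclopropylamino group in place the two configurations as drawn are not separated at this position. With that centre drawn alike, cyclopropyl in place of pyridin-2-yl on an amine nitrogen gives a number 1.70 log units lower from compound 1 to compound 3 (beyond the scatter); this isolates the group exchange, whereas the earlier step, a number 1.58 log units lower from compound 1 to compound 2 (beyond the scatter), carried the exchange together with a change in drawn configuration. The size of the exchange therefore holds up when configuration is set aside, and the comparison of the cyclopropylamino pair rests on one point: the fact that compounds 2 and 3 differ only in the configuration as drawn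

As far as these compounds go, the configuration test covers the cyclopropylamino pair alone, so it remains open whether the same centre is equally silent in this assay when pyridin-2-yl sits on the amine nitrogen. Also open, from the compounds shown here alone, is how other groups on that nitrogen, such as phenyl, isopropyl or a longer alkyl chain, would read in this assay against the cyclopropyl and pyridin-2-yl compounds.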